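From piperidin-4-yl to methyl on the aromatic nitrogen

The source may report more compounds than this note shows. Statements on the series, on what has been measured and on what is new or still open speak of the compounds shown alone.

In a functional assay on MCF7 cells (Homo sapiens) for antiproliferative activity, read by MTT assay, with a stated time of 72 h (on this read-out higher numbers stand for weaker inhibition and lower numbers for stronger inhibition), compound 1 (`CC(Oc1nc(N)nc2ccc(-c3cnn(C4CCNCC4)c3)cc12)c1c(Cl)ccc(F)c1Cl`) gives 1240 nM, and compound 2 (`CC(Oc1ncnc2ccc(-c3cnn(C4CCNCC4)c3)cc12)c1c(Cl)ccc(F)c1Cl`) gives 2670 nM, the higher of the two numbers. Compound 3 (`CC(Oc1ncnc2ccc(-c3cnn(C)c3)cc12)c1c(Cl)ccc(F)c1Cl`) keeps the core of compound 2 but carries methyl in place of piperidin-4-yl on an aromatic nitrogen. For the measured compounds named here, no measured step touches this place. Going by the values given here, the only step available, a 2.2-fold higher number from compound 1 to compound 2 (0.33 log units; beyond the scatter), is modest, lies just beyond the scatter and concerns hydrogen in place of amino on an aromatic carbon, so it offers only a rough sense of scale. A modest-to-moderate rise in the number is therefore expected in this assay, meaning weaker inhibition, though with low confidence. The expected change is a 1.9-fold higher number from compound 2 to compound 3 (0.27 log units; within the scatter). For compound 3 the estimated value is 5000 nM, with an expected range of 1800 nM to 14000 nM.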

Compound 3, half-maximal inhibitory concentration: 22600 nM
Estimate against measurement, compound 3: 4.5-fold (0.66 log units) below; the whole stated range lies below it.
By their numbers in this assay, from the lowest: compound 1; then compound 2; then compound 3.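

Working notes: the group on the aromatic nitrogen of the five-membered ring carries more weight in this assay than the earlier amino-to-hydrogen change. Exchanging 1-(piperidin-4-yl)-1H-pyrazol-4-yl for 1-methyl-1H-pyrazol-4-yl gives an 8.5-fold higher number from compound 2 to compound 3 (0.93 log units; beyond the scatter), a larger step than a 2.2-fold higher number from compound 1 to compound 2 (0.33 log units; beyond the scatter). Within this pair, inhibition is therefore stronger with piperidin-4-yl than with methyl, so this place is sensitive to substitution and methyl is a poor replacement here.

The pair cannot separate the contribution of the piperidine nitrogen from that of the ring or the size of the group: a cyclohexyl group and an open 2-aminoethyl chain on the same nitrogen would pull these apart. Also open is whether an amino group on the core would give the same step with methyl in place, and no measurement shown here explains the drop.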